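Two Aryl Swaps on a Shared Core, One Outcome Unknown

The source may hold more compounds than are shown below. What is called first, only, known or untested is meant among the compounds shown, and "the series" means these compounds.

Compound 1: `C=CCn1c(=O)/c(=C\c2cccc(Cl)c2Cl)[nH]c(=O)/c1=C\c1ccccc1OC`; in a functional assay on HL-60 cells (Homo sapiens) for cytotoxicity, read by CCK-8 assay, with a stated time of 72 h (a higher number here means a weaker inhibitor, a lower number a stronger inhibitor), compound 1 gives 2000 nM.
Compound 2: `C=CCn1c(=O)/c(=C\c2ccc(F)c(Br)c2)[nH]c(=O)/c1=C\c1ccccc1OC`; in this assay compound 2 is reported as "not active" (no number reported).

Compound 2 therefore stands without a single number, unlike compound 1, which does give a value. Compound 3, `C=CCn1c(=O)/c(=C\c2ccccc2F)[nH]c(=O)/c1=C\c1ccccc1OC`, differs from compound 2 by 2-fluorophenyl in place of 3-bromo-4-fluorophenyl on a double-bonded chain carbon bound to an aromatic carbon. Among the measured compounds shown here, with no measured step between the two, the direction and size of the change remain open. Compound 3 is expected to fall near 6000 nM, within a range of 1500 nM to 40000 nM.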

Compound 3, half-maximal inhibitory concentration: 18500 nM
Compound 3: the middle estimate sits 3.1-fold (0.49 log units) below what was measured, within the range that was stated.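

Among the compounds shown here, at the double-bonded chain carbon bound to an aromatic carbon, 2-fluorophenyl in place of 2,3-dichlorophenyl gives a 9.3-fold higher number from compound 1 to compound 3 (0.97 log units; beyond the scatter) in this assay, the first readable change at this position. Compound 2 has no number, so its step to compound 3 cannot be read. Nothing available here accounts for the shift. The compounds shown leave open how a phenyl carrying an amine or a carboxylic acid would read at this place, and whether the 2-methoxyphenyl group on the other side of the shared core matters.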